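Removing the ester from compound 1 on the shared core

The source may hold more compounds than are shown below. What is called first, only, known or untested is meant among the compounds shown, and "the series" means these compounds.

Three compounds of the shared core have numbers in a functional assay with Rattus norvegicus as the target; a lower number here means a stronger inhibitor, a higher number a weaker inhibitor. Compound 1 `COC(=O)c1cc(OC)c2oc(=O)c(=O)[nH]c2c1` gives 3400 nM and stands lowest of the three. Its nearest neighbour is compound 2 `CCOC(=O)c1ccc2oc(=O)c(=O)[nH]c2c1`, which gives 10000 nM, a gap beyond the scatter; furthest is compound 3 `O=c1[nH]c2cc(C(F)(F)F)ccc2oc1=O`, which gives 100000 nM, also well beyond the scatter.

Compound 4 `COc1cccc2[nH]c(=O)c(=O)oc12` is not yet measured. It differs from compound 1 in one place: hydrogen in place of methoxycarbonyl on an aromatic carbon. The methoxy group and the rest of the core are kept.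

Going by the values given here, one measured step touches the same region of the core: a 10-fold higher number from compound 2 to compound 3 (1.00 log units; beyond the scatter). Where the ester was exchanged for trifluoromethyl, the number rose clearly, so an ester at this position goes with the lower numbers seen so far, with compound 1 and compound 2 both below compound 3. Losing the ester altogether in compound 4 is therefore expected to move the number in the same direction, by a step of roughly an 8.8-fold higher number from compound 1 to compound 4 (0.95 log units; beyond the scatter) in this assay, and the outcome is uncertain since no compound with hydrogen at this position has been measured. For compound 4 the expected value is 30000 nM, with a range from 8000 nM to 120000 nM.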

Compound 4, half-maximal inhibitory concentration: 7000 nM
For compound 4 the middle estimate is 4.3-fold (0.63 log units) above the measured one; the measured number lies below the stated range.
By their numbers in this assay, from the lowest: compound 1; then compounds 4 and 2 (each within the scatter of the next); then compound 3.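

In this assay, a 2.1-fold higher number from compound 1 to compound 4 (0.31 log units; beyond the scatter), so removing methoxycarbonyl altogether, with the methoxy group kept, costs far less at this aromatic carbon than the earlier exchange suggested. That exchange, a 10-fold higher number from compound 2 to compound 3 (1.00 log units; beyond the scatter), is the larger step, but it was read on a core without the methoxy group, so compound 4 gives 7000 nM without the ester and trifluoromethyl and hydrogen cannot be ranked directly against each other at this position. No measured evidence is available to explain why these two steps differ in size.

What the compounds shown leave open is how the same position responds to other replacements for methoxycarbonyl on the core of compound 4, such as a carboxylic acid, an amine or a longer chain, since only hydrogen, trifluoromethyl and two esters are covered so far. The contribution of the methoxy group also remains unresolved, as no pair of compounds shown differs in that group alone, and a hydrogen at this position on the core of compound 2 would be needed to read the ester step without it.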